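This account rests on a few compounds, and the source may have more. Where it says the series, first, only, none or still open, it means among the compounds named here.

Of the compounds shown here, three have been measured in an assay on cells (1-87 tumor cell line) for inhibition of Polyunsaturated fatty acid 5-lipoxygenase (Homo sapiens), with a stated time of 5 min; a lower number here means a stronger inhibitor, a higher number a weaker inhibitor. Compound 1 `NS(=O)(=O)c1ccc(N2C(=O)CC(C3CCCCC3=O)C2=O)cc1` gives 21300 nM, the second highest of the three numbers. Compound 3 `O=C1CCCCCC1C1CC(=O)N(c2ccccc2)C1=O` gives 18400 nM, a number within the scatter of compound 1, so no order between these two can be read. Compound 2 `CC(=O)CC1CC(=O)N(c2ccccc2)C1=O` gives 62400 nM, a number beyond the scatter and higher than that of compound 1. Compound 4 `O=C1CCCCC1C1CC(=O)N(c2ccccc2)C1=O` has not been measured. It differs from compound 1 in one place: hydrogen in place of sulfamoyl on an aromatic carbon. Going by the values given here, no measured pair shows this change on its own. Compound 3 also lacks a sulfamoyl group and gives 18400 nM, a number close to compound 1. The step of a 1.1-fold lower number from compound 1 to compound 4 (0.03 log units; within the scatter) is expected to stay within the scatter. Compound 4 is expected to give 20000 nM, with a range from 8000 nM to 50000 nM.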

Compound 4, half-maximal inhibitory concentration: 78300 nM
Compound 4: middle estimate off by 3.9-fold (0.59 log units), on the low side, and the stated range ends below it.
By their numbers in this assay, from the lowest: compounds 3 and 1 (each within the scatter of the next); then compounds 2 and 4 (each within the scatter of the next).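

Taking the sulfamoyl group off the aromatic ring, a change no earlier pair showed on its own, gives a 3.7-fold higher number from compound 1 to compound 4 (0.57 log units; beyond the scatter). So at this place on the ring the group is not interchangeable with hydrogen: compound 4 is the weaker inhibitor, by a modest step beyond the scatter. Nothing given here explains this difference. On these data alone, whether an amine or a carboxylic acid at the same place would keep the number of compound 1 remains open. So does whether adding a sulfamoyl group would change compound 2 or compound 3 in the same way.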